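One Aromatic Substituent Exchanged: Chloro to Methoxycarbonyl

This account rests on a few compounds, and the source may have more. Where it says the series, first, only, none or still open, it means among the compounds named here.

Three measured compounds share one core and differ only in the group carried on a six-membered aromatic ring of carbon only. Compound 1 `N#Cc1ccc(Cn2cc(/C=C3\NC(=O)NC3=O)c3ccccc32)cc1` carries a cyano group there, and in a functional assay on MDA-MB-231 cells (Homo sapiens) for antiproliferative activity, read by trypan blue exclusion, with a stated time of 24 h (a higher number here means a weaker inhibitor, a lower number a stronger inhibitor), compound 1 gives 17600 nM. Compound 2 `O=C1NC(=O)/C(=C/c2cn(Cc3ccc([N+](=O)[O-])cc3)c3ccccc23)N1` carries a nitro group, and in this assay compound 2 gives 23300 nM. Compound 3 `O=C1NC(=O)/C(=C/c2cn(Cc3ccc(Cl)cc3)c3ccccc23)N1` carries a chloro group, and in this assay compound 3 gives 25300 nM, the highest of the three numbers, though the gaps are small: a 1.4-fold higher number from compound 1 to compound 3 (0.16 log units; within the scatter) and a 1.1-fold higher number from compound 2 to compound 3 (0.04 log units; within the scatter), while between the other two compounds a 1.3-fold higher number from compound 1 to compound 2 (0.12 log units; within the scatter). None of these exchanges moves the number beyond the scatter.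

Compound 4 `COC(=O)c1ccc(Cn2cc(/C=C3\NC(=O)NC3=O)c3ccccc32)cc1` has not yet been measured. It arises from compound 3 by a change at the same place: methoxycarbonyl in place of chloro on an aromatic carbon. All three measured steps swap one small group for another at this position, and each stayed within the scatter, so this fourth exchange is also expected to produce no step beyond the scatter, that is a 1.2-fold lower number from compound 3 to compound 4 (0.06 log units; within the scatter). Compound 4 is therefore estimated to give 22000 nM in this assay, with an expected range from 9000 nM to 55000 nM.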

Compound 4, half-maximal inhibitory concentration: 18400 nM
Beside the measured number, compound 4's estimate is 1.2-fold (0.08 log units) above it, within the range that was stated.
By their numbers in this assay, from the lowest: compounds 1, 4, 2 and 3 (each within the scatter of the next).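

Exchanging chloro (1 heavy atom, 0 hydrogen-bond acceptors) for methoxycarbonyl (4 heavy atoms, 2 hydrogen-bond acceptors, 1 double bond outside aromatic rings) on this aromatic carbon gives, in this assay, a 1.4-fold lower number from compound 3 to compound 4 (0.14 log units; within the scatter), so even this added bulk of atoms does not move the number beyond the scatter. Measured against the other two groups, methoxycarbonyl behaves the same way, with a 1.3-fold lower number from compound 2 to compound 4 (0.10 log units; within the scatter) and a 1.0-fold higher number from compound 1 to compound 4 (0.02 log units; within the scatter), which extends the flat picture at this position from three groups to four. Nothing measured here bears on why these four groups give such similar numbers.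

The compounds shown leave open whether a group of a different kind at this position, such as an amine, a carboxylic acid or a longer alkyl chain, would produce a step beyond the scatter. They also leave open whether the hydrogen on the aromatic carbon itself, with no substituent at all, would give a number in the same range as these four compounds.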